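A few compounds are considered here, and "the series" means these few. Any claim that something is new, unique, unknown or untested is made for them only; others in the source may bear on it.

Measured so far in a physicochemical assay for lipophilicity, read by HPLC, at pH 7.5 (a lower number here means a more polar compound, a higher number a more lipophilic compound), are three compounds:

Compound 1 `CC[C@@H](Nc1c(C#N)c(-c2ccc(-c3ccccc3F)cc2)nc2cnccc12)C(N)=O` reads 2.7
Compound 2 `CCOc1ccccc1-c1ccc(-c2nc3cnccc3c(N[C@H](CC)C(=O)NS(=O)(=O)C3CC3)c2C#N)cc1` reads 2.3
Compound 3 `CCOc1ccccc1-c1ccc(-c2nc(NC(C)C(=O)O)c3ccncc3n2)cc1` reads 2.1

Compound 2 (2.3) cannot be told apart from compound 3 (2.1), since the two lie within the usual scatter. Compound 1 (2.7) is higher than compound 2, and that gap goes beyond the scatter.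

The next compound is compound 4 (`CCOc1ccccc1-c1ccc(-c2nc3cnccc3c(N[C@H](CC)C(=O)O)c2C#N)cc1`). It keeps the frame of compound 2, but hydroxy stands in place of (cyclopropylsulfonyl)amino on a carbonyl carbon (hydroxy in place of (cyclopropylsulfonyl)amino on a carbonyl carbon). The end group thus changes from (cyclopropylsulfonyl)carbamoyl to carboxy.

Among the compounds with values here, no two measured compounds differ in one place alone, so no measured step can guide the forecast. The nearest guide is compound 3, which also carries a carboxy group, on another core, and reads 2.1 in this assay. What is expected is a number 0.30 log units lower from compound 2 to compound 4 (within the scatter) as a small downward step that may stay within the scatter. The estimated value for compound 4 is 2 with an expected range from 1.5 to 2.5 in this measurement.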

Compound 4, distribution coefficient: 2.1
Beside the measured number, compound 4's estimate is 0.10 log units below it; the range from low to high includes it.
By their numbers in this assay, from the lowest: compounds 3, 4 and 2 (each within the scatter of the next); then compound 1.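

In this assay, within the data shown here, the first step between two compounds that differ in one place is a number 0.20 log units lower from compound 2 to compound 4 (within the scatter). On this carbonyl carbon, then, (cyclopropylsulfonyl)amino, with its 7 heavy atoms, sulfur and three-membered ring, gives way to a single hydroxy oxygen, yet the two compounds cannot be told apart in this measurement. No measurement shown here accounts for this result.

On these data alone, this is a single step on a single frame, so it remains open whether the end group at this position has any effect on the reading here that goes beyond the scatter. Methoxy or dimethylamino on the same carbonyl carbon could test this, and the same exchange on another core would show whether the result carries over.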